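The source may hold more compounds than are shown below. What is called first, only, known or untested is meant among the compounds shown, and "the series" means these compounds.

Compound 1 `Nc1nc2c(ncn2/C=C2/C[C@H]2[C@@H](O)CO)c(=O)[nH]1` gives 299000 nM in an ADME assay on HFF cells (Homo sapiens) for cytotoxicity, read by neutral red uptake; on this read-out higher numbers stand for lower toxicity in this test and lower numbers for higher toxicity in this test.
Compound 2 `Nc1nc2c(ncn2/C=C2\C[C@@H]2[C@@H](O)CO)c(=O)[nH]1` reaches only the limit of the assay, > 300000 nM, in this assay.
Compound 3 `Nc1ncnc2c1ncn2/C=C1\C[C@@H]1[C@@H](O)CO` likewise stops at the limit, > 300000 nM, in this assay.

All three measured compounds sit at or just under the top of what this assay can report, so none of them is clearly toxic to these cells. Compound 2 stands at the limit, and only a limit is known for it. Going by the values given here, the one measured step is a number no lower from compound 1 to compound 2 (the limit leaves the size open), and its size cannot be read because the limit of > 300000 nM in this assay, at which 2 of the 3 values shown sit, caps the numbers; the pair is otherwise alike because of the fact that compounds 1 and 2 differ only in the configuration as drawn.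

Compound 4 `Nc1nc2c(ncn2/C=C2\C[C@H]2[C@H](O)CO)c(=O)[nH]1` is the next compound. Compared with compound 2, (the two compounds have the same atoms and bonds and differ only in configuration as drawn: 2 of 3 stereo elements differ; a stereocentre at a saturated ring carbon is drawn S in compound 2 and R in compound 4; a stereocentre at a saturated chain carbon is drawn R in compound 2 and S in compound 4). Among the compounds with values here, the only measured step is also a pure change of configuration, and it produced no readable movement, so for compound 4 no step beyond the scatter is expected, and the estimated step is a number no higher from compound 2 to compound 4 (the limit leaves the size open). Compound 4 is therefore expected to give about 300000 nM, within a range of 150000 nM to 600000 nM, most likely again as a limit rather than a number.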

Compound 4, half-maximal cytotoxic concentration: > 300000 nM
Compound 4 gave a limit, no number (the forecaster's own chance of this, stated with the estimate: 70%); the middle value sits exactly at the limit.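

Compound 4 stops at a limit of the assay, > 300000 nM, in this assay, so this further arrangement of the stereocentres, with the double bond drawn E as in compound 2, also yields no exact number. Unlike the step from compound 1 to compound 2, this change involves a stereocentre at a saturated chain carbon as well as one at a saturated ring carbon, while all atoms and bonds stay the same: the fact that compounds 2 and 4 differ only in the configuration as drawn. The new measurement also gives a number no lower from compound 1 to compound 4 (the limit leaves the size open). Neither new step can be read in size, and what caps them is this: the limit of > 300000 nM in this assay, at which 3 of the 4 values shown sit.

As far as these compounds go, how far apart compound 2 and compound 4 really lie remains unknown. Also open, from the compounds shown here alone, is whether a change of atoms rather than of configuration, such as a carboxylic acid or a longer chain on the side chain, would give a clearly lower number in this assay.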